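Swapping the Pyridine Ring for Phenyl in Compound 1

This account rests on a few compounds, and the source may have more. Where it says the series, first, only, none or still open, it means among the compounds named here.

Compound 1 `N=C(NCCCc1c[nH]cn1)NCCC(c1ccc(F)cc1)c1ccccn1` gives the lowest of the three measured numbers in a functional assay on ileum for antagonist activity at histamine H1 receptor (Cavia porcellus) (a lower number here means tighter binding, a higher number weaker binding), with 22.4 nM. Compound 2 `N=C(NCCCc1c[nH]cn1)NCCC(c1ccc(Br)cc1)c1ccccn1` gives 120 nM, and compound 3 `N=C(NCCCc1c[nH]cn1)NCCC(c1ccccn1)c1ccccc1F` gives 437 nM. The step of a 5.4-fold higher number from compound 1 to compound 2 (0.73 log units; beyond the scatter) was modest, while the step of a 20-fold higher number from compound 1 to compound 3 (1.29 log units; beyond the scatter) was large; both show that altering the aryl groups on the saturated chain carbon moves the number beyond the scatter. Compound 4 `N=C(NCCCc1c[nH]cn1)NCCC(c1ccccc1)c1ccc(F)cc1` differs from compound 1 by phenyl in place of pyridin-2-yl on a saturated chain carbon bound to an aromatic carbon and a saturated chain carbon. Going by the values given here, no measured step touches the pyridin-2-yl ring itself, so the guidance is only indirect. A modest weakening is expected, with the step of a 2.2-fold higher number from compound 1 to compound 4 (0.35 log units; beyond the scatter). Compound 4 is therefore estimated at 50 nM, within a range from 15 nM to 200 nM.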

Compound 4, dissociation constant: 34.7 nM
Compound 4: the middle estimate sits 1.4-fold (0.16 log units) above what was measured; the measured number falls inside the stated range.
By their numbers in this assay, from the lowest: compounds 1 and 4 (each within the scatter of the next); then compound 2; then compound 3.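

Going by these compounds alone, this is the first change to the pyridin-2-yl ring itself: in this assay, phenyl in its place gives a 1.5-fold higher number from compound 1 to compound 4 (0.19 log units; within the scatter). So, in this pair, losing the ring nitrogen, the one hydrogen-bond acceptor that leaves with pyridin-2-yl, does not separate the two compounds. No measured evidence accounts for this result.

Still open, as far as these compounds go, is whether a non-aromatic group at this place, such as an amine or a carboxylic acid, would be tolerated as well. It is also unknown whether phenyl would match pyridin-2-yl alongside the 4-bromophenyl of compound 2.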